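A Fluorine Added Beside the Chlorophenyl Ring's Attachment

This account rests on a few compounds, and the source may have more. Where it says the series, first, only, none or still open, it means among the compounds named here.

For the measured compounds named here, compound 1 `CC(C)(C)n1ncc(OCc2nnc(-c3ccc(Cl)cc3)o2)c(Cl)c1=O` is a chlorophenyl-bearing member of a small series, and in a physicochemical assay for lipophilicity (a higher number here means a more lipophilic compound, a lower number a more polar compound), compound 1 gives 3.09, the lower of the two numbers so far. Going by the values given here, its partner compound 2 `CC(C)(C)n1ncc(OCc2nnc(-c3ccc(C(F)(F)F)cc3)o2)c(Cl)c1=O` carries a trifluoromethyl group in place of the chloro; in this assay compound 2 gives 3.66, and the step of a number 0.57 log units higher from compound 1 to compound 2 (beyond the scatter) is the only measured step in the set. Compound 3 `CC(C)(C)n1ncc(OCc2nnc(-c3ccc(Cl)cc3F)o2)c(Cl)c1=O` is not yet measured; it differs from compound 1 by fluoro in place of hydrogen on an aromatic carbon. Among the compounds with values here, no measured step matches a fluoro for hydrogen exchange, so the step from compound 1 to compound 2 bears on it only loosely, and a single fluorine is a much smaller change than that one. A small rise, possibly inside the scatter, is expected for compound 3, a number 0.16 log units higher from compound 1 to compound 3 (within the scatter). Compound 3 is therefore estimated at 3.25, between 3 and 3.5.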

Compound 3, partition coefficient: 3.23
For compound 3 the middle estimate is 0.02 log units above the measured one; measured number inside the range.
By their numbers in this assay, from the lowest: compounds 1 and 3 (each within the scatter of the next); then compound 2.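

In this assay, the step for fluoro in place of hydrogen, on the aromatic carbon ortho to a large group, is a number 0.14 log units higher from compound 1 to compound 3 (within the scatter) and so cannot be told apart from the spread of repeated measurements. The only earlier step, for trifluoromethyl in place of chloro, was a number 0.57 log units higher from compound 1 to compound 2 (beyond the scatter), so this position has now shown that a single fluoro can be added to compound 1 without a clear difference in this read-out. Nothing here independently explains either step.

Going by these compounds, whether a larger group on that same carbon, such as an amine or a methoxy group, would give a difference beyond the scatter remains open. So does whether the same fluoro exchange would read alike with trifluoromethyl in place of the chloro group.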